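This account rests on a few compounds, and the source may have more. Where it says the series, first, only, none or still open, it means among the compounds named here.

Among the measured compounds shown here, in a functional assay on K562 cells (Homo sapiens) for inhibition, read by MTT assay, with a stated time of 48 h (on this read-out higher numbers stand for weaker inhibition and lower numbers for stronger inhibition), compound 1 `C=CC(=O)Nc1ccc(-c2cn([C@@H]3CN[C@H](C(=O)Nc4ccc(Cl)c(C(F)(F)F)c4)C3)nn2)cn1` gives 3860 nM, the lowest of the three numbers measured so far. Compound 4 `Nc1nc2ccc(-c3cn([C@@H]4CN[C@H](C(=O)Nc5ccc(Cl)c(C(F)(F)F)c5)C4)nn3)nc2s1` has not yet been measured. It keeps the core of compound 1 but exchanges one group on an aromatic carbon of a five-membered aromatic ring with 3 nitrogen: a group of 10 heavy atoms (6 carbon, 3 nitrogen, 1 sulfur; one five-membered aromatic ring with 2 hetero atoms, one six-membered aromatic ring with 1 hetero atom) in place of a group of 11 heavy atoms (8 carbon, 2 nitrogen, 1 oxygen; one six-membered aromatic ring with 1 hetero atom), on an aromatic carbon. The group that leaves is 6-((vinylcarbonyl)amino)pyridin-3-yl. For the measured compounds named here, the entering group also occurs in compound 2 `CC(C)(C)OC(=O)N1C[C@@H](n2cc(-c3ccc4nc(N)sc4n3)nn2)C[C@H]1C(=O)Nc1ccc(Cl)cc1Cl` and compound 3 `CC(C)(C)OC(=O)N1C[C@@H](n2cc(-c3ccc4nc(N)sc4n3)nn2)C[C@H]1C(=O)Nc1ccc(Br)cc1`, but both differ from compound 4 elsewhere too, so no measured step isolates this exchange. Going by the values given here, the one measured step, a 3.3-fold higher number from compound 2 to compound 3 (0.51 log units; beyond the scatter), concerns a different place, with 4-bromophenyl in place of 2,4-dichlorophenyl on an amide-type nitrogen. Still, compound 2 at 8940 nM and compound 3 at 29200 nM both read higher than compound 1, so a modest rise, meaning weaker inhibition, is expected in this assay. The expected size of the change is a 1.8-fold higher number from compound 1 to compound 4 (0.26 log units; within the scatter). Compound 4 is estimated at 7000 nM, with an expected range from 2500 nM to 20000 nM.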

Compound 4, half-maximal inhibitory concentration: 26200 nM
For compound 4 the middle estimate is 3.7-fold (0.57 log units) below the measured one, outside the stated range (above it).
By their numbers in this assay, from the lowest: compound 1; then compound 2; then compounds 4 and 3 (each within the scatter of the next).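

In this assay, this position, on an aromatic carbon of the five-membered aromatic ring with 3 nitrogen, proves sensitive to what it carries, something the earlier step on the amide-type nitrogen could not show. With the rest of the molecule unchanged, putting the group with one five-membered and one six-membered aromatic ring in place of 6-((vinylcarbonyl)amino)pyridin-3-yl gives a 6.8-fold higher number from compound 1 to compound 4 (0.83 log units; beyond the scatter), so this exchange weakens inhibition here. Nothing available explains why the number rises.

The exchange replaces the whole group at once, so the compounds shown cannot separate the part played by the vinylcarbonyl amide from that of the ring system. Going by these compounds, how a 6-aminopyridin-3-yl or a 6-(propanoylamino)pyridin-3-yl group would read at this position remains open.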